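Swapping the acyl sulfonamide group in compound 2

A few compounds are considered here, and "the series" means these few. Any claim that something is new, unique, unknown or untested is made for them only; others in the source may bear on it.

Values in a functional assay on the whole organism for inhibition, with Rattus norvegicus as the target (a lower number here means that less compound is needed, a higher number that more compound is needed for the effect), for the measured compounds:

- Compound 1 `Cc1ccc(OC(Cc2ccc(Cl)cc2)C(=O)O)cc1` gives > 25 mg/kg as a limit
- Compound 2 `CC(C)c1ccc(OC(C)(Cc2ccc(Cl)cc2)C(=O)NS(C)(=O)=O)cc1` gives 5 mg/kg as a number
- Compound 3 `Cc1ccccc1S(=O)(=O)NC(=O)C(C)(Cc1ccc(Cl)cc1)Oc1ccc(C(C)C)cc1` gives > 10 mg/kg as a limit

Going by the values given here, compound 2 holds the only true number here, as the other two values are limits. Compound 4 `CC(C)c1ccc(OC(C)(Cc2ccc(Cl)cc2)C(=N)NO)cc1` differs from it by one change, (a group of 4 heavy atoms (1 carbon, 2 nitrogen, 1 oxygen; no ring) in place of a group of 7 heavy atoms (2 carbon, 1 nitrogen, 3 oxygen, 1 sulfur; no ring), on a saturated chain carbon bound to an oxygen on an aromatic ring and two saturated chain carbons), while the rest of the structure stays the same. Among the compounds with values here, only one measured step touches the departing group, an at least 2.0-fold higher number from compound 2 to compound 3 (0.30 log units; that floor lies within the scatter), and it altered only the methyl on the sulfonyl sulfur. That step gives a weak hint of direction and little guide to size, so a higher number is expected in this assay for compound 4, and a reported limit is quite possible. The expected change is a 4.0-fold higher number from compound 2 to compound 4 (0.60 log units; beyond the scatter), towards more compound needed. For compound 4 the estimate is 20 mg/kg, with an expected range from 6 mg/kg to 60 mg/kg in this estimate.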

Compound 4, dose for half-maximal effect: > 10 mg/kg
Compound 4: no number, only a limit; the forecaster's own chance of this, stated with the estimate: 55%; the middle value is on the limit's open side.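

In this assay, replacing the whole (methylsulfonyl)carbamoyl group, not just the methyl on its sulfur, gives an at least 2.0-fold higher number from compound 2 to compound 4 (0.30 log units; that floor lies within the scatter). From the compounds shown here alone, the value of compound 4 is a limit, so this step is only a floor and its true size remains unknown. Compound 3 and compound 4 both end at a limit rather than a number, so neither change to this group of compound 2 gives a measured value: the limit of > 10 mg/kg in this assay, at which 2 of the 4 values shown sit.

Going by these compounds, how a plain amide or a tetrazole at this place would read in this assay remains open.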